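The compounds below may be only part of what the source reports. "The series", "measured", "known", "first", "only" and "open" are said of these compounds alone.

Measured compounds: compound 1 `COc1cc(-c2cc(/C=C/C(=O)c3ccc(Cl)c(Cl)c3)[nH]n2)cc(OC)c1OC` with 104%, and compound 2 `COc1ccc(-c2cc(/C=C/C(=O)c3ccc(N)cc3)[nH]n2)cc1OC` with 96%, both in a functional assay on Hs-578T cells (Homo sapiens) for cytotoxicity, read by sulforhodamine B assay, with a stated time of 48 h, tested at 1 uM; on this read-out lower numbers stand for a stronger effect and higher numbers for a weaker effect at the one concentration tested.

Going by the values given here, compound 1 gives one of only two numbers, and its gap to compound 2 lies within the usual scatter, so neither stands apart. Compound 3 `COc1ccc(C(=O)/C=C/c2cc(-c3cc(OC)c(OC)c(OC)c3)n[nH]2)cc1OC` is not yet measured. It differs from compound 1 by 3,4-dimethoxyphenyl in place of 3,4-dichlorophenyl on a carbonyl carbon. Among the compounds with values here, no step between measured compounds is known, so the expectation rests on compound 1 alone, whose 104% shows little effect. The step of a number 6 percentage points lower from compound 1 to compound 3 (within the scatter) is expected to be none beyond the scatter. Compound 3 is therefore estimated at 98%, within 84% to 110%.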

Compound 3, a percentage reported as activity, at one concentration (the size of the read-out at that concentration, not a potency): 91%
The estimate for compound 3 lay 7 percentage points above the measured number, and the stated range covers the measured number.
By their numbers in this assay, from the lowest: compounds 3, 2 and 1 (each within the scatter of the next, the first and the last beyond it).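

Going by these compounds alone, the change at the carbonyl carbon gives the first step here that exceeds the usual scatter: 3,4-dimethoxyphenyl in place of 3,4-dichlorophenyl gives a number 13 percentage points lower from compound 1 to compound 3 (beyond the scatter) in this assay. This position therefore responds to the group it carries, but only modestly, as compound 3 still reads 91% at the one concentration tested. Nothing at hand explains the step.

From the compounds shown here alone, it remains open whether a carboxylic acid or a pyridine ring at this position would strengthen the effect further. Going by these compounds, whether the same change would give a similar step on a different core also remains unknown.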